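The source may hold more compounds than are shown below. What is called first, only, known or untested is meant among the compounds shown, and "the series" means these compounds.

Measured compounds:
- compound 1 `CCc1ccccc1-n1nncc1CN1C(=O)C2(C(C#N)=C(N)Oc3c(N)cc4nc5ccccc5nc4c32)c2ccccc21`, in a functional assay on HCT-116 cells (Homo sapiens) for antiproliferative activity, read by MTT assay, with a stated time of 48 h (on this read-out lower numbers stand for stronger inhibition and higher numbers for weaker inhibition), compound 1 gives 10300 nM
- compound 2 `N#CC1=C(N)Oc2c(N)cc3nc4ccccc4nc3c2C12C(=O)N(Cc1cnnn1-c1ccccc1Cl)c1ccccc12`, compound 2 gives only the limit > 50000 nM in this assay
- compound 3 `COc1ccc(-n2nncc2CN2C(=O)C3(C(C#N)=C(N)Oc4c(N)cc5nc6ccccc6nc5c43)c3ccccc32)cc1`, compound 3 likewise gives only the limit > 50000 nM in this assay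

Compound 3 thus stands at the limit of this assay and has no number of its own, as does compound 2 (the limit of > 50000 nM in this assay, at which 2 of the 3 values shown sit). Compound 4 `CCc1cccc(C)c1-n1nncc1CN1C(=O)C2(C(C#N)=C(N)Oc3c(N)cc4nc5ccccc5nc4c32)c2ccccc21` differs from compound 3 in that (2-ethyl-6-methylphenyl in place of 4-methoxyphenyl on an aromatic nitrogen). The step that bears on it is an at least 4.8-fold higher number from compound 1 to compound 3 (0.68 log units; beyond the scatter), which runs in the opposite direction: the 4-methoxyphenyl weakened the compound. The step that the two limits leave unreadable from compound 2 to compound 3 gives no size. The step of an at least 4.8-fold higher number from compound 1 to compound 2 (0.68 log units; beyond the scatter) shows that not every group on that nitrogen keeps the activity of compound 1. Since 2-ethyl-6-methylphenyl is closer to the 2-ethylphenyl of compound 1, compound 4 is expected to regain a measurable number, estimated as an at least 3.3-fold lower number from compound 3 to compound 4 (0.52 log units; beyond the scatter). Compound 4 is therefore estimated at 15000 nM, in a range from 5000 nM to 50000 nM.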

Compound 4, half-maximal inhibitory concentration: > 50000 nM
Compound 4 gave a limit, no number (the forecaster's own chance of this, stated with the estimate: 35%); at least 3.3-fold (0.52 log units) between middle value and limit.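

In this assay, a single methyl added to the 2-ethylphenyl group gives an at least 4.8-fold higher number from compound 1 to compound 4 (0.68 log units; beyond the scatter), so keeping the ethyl group does not by itself keep a measurable number. The earlier compounds showed this loss only where the 2-ethylphenyl was replaced, whereas here it is kept and extended, and compound 1 alone among the compounds shown still has a number of its own: the limit of > 50000 nM in this assay, at which 3 of the 4 values shown sit. The steps among compound 2, compound 3 and compound 4 join limit to limit and cannot be read.

The compounds shown leave open whether a plain phenyl, a 2-methylphenyl or a 2-isopropylphenyl on that ring nitrogen would give a measurable number. They also leave open whether a 2-ethyl-6-fluorophenyl would behave like the 2-ethyl-6-methylphenyl of compound 4.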